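A few compounds are considered here, and "the series" means these few. Any claim that something is new, unique, unknown or untested is made for them only; others in the source may bear on it.

Compounds measured in a functional assay on HGC-27 cells (Homo sapiens) for inhibition, read by MTT assay, with a stated time of 72 h; on this read-out higher numbers stand for weaker inhibition and lower numbers for stronger inhibition:
compound 1 `Cc1cc(N2CC[C@@H](C)[C@@H](N(C)c3ncnc4[nH]ccc34)C2)n2nc(SCC3CCCCC3)nc2n1` — 11500 nM
compound 2 `Cc1cc(N2CC[C@@H](C)[C@@H](N(C)c3ncnc4[nH]ccc34)C2)n2nc(SCC3CC3)nc2n1` — 21400 nM
compound 3 `Cc1cc(N2CC[C@@H](C)[C@@H](N(C)c3ncnc4[nH]ccc34)C2)n2nc(SCCc3ccccc3)nc2n1` — 11800 nM

Compound 1 gives the lowest of the three numbers, but its gaps to compound 3 and to compound 2 both sit within the scatter, so no ordering among the three can be claimed. The steps out of compound 1 are a 1.9-fold higher number from compound 1 to compound 2 (0.27 log units; within the scatter) and a 1.0-fold higher number from compound 1 to compound 3 (0.01 log units; within the scatter); between the other two the step is a 1.8-fold lower number from compound 2 to compound 3 (0.26 log units; within the scatter). Each of the three variations on the saturated chain carbon bound to a sulfur leaves the read-out essentially where it was.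

Compound 4 `Cc1cc(N2CC[C@@H](C)[C@@H](N(C)c3ncnc4[nH]ccc34)C2)n2nc(SCc3ccc(Br)cc3)nc2n1` is not yet measured. Relative to compound 1 the change is 4-bromophenyl in place of cyclohexyl on a saturated chain carbon bound to a sulfur. Among the compounds with values here, the closest precedent, an aromatic ring in place of the cyclohexyl at the same place, is a 1.0-fold higher number from compound 1 to compound 3 (0.01 log units; within the scatter); the cyclopropyl variation, a 1.9-fold higher number from compound 1 to compound 2 (0.27 log units; within the scatter), likewise stays within scatter. No step beyond the scatter is therefore expected for compound 4 in this assay, and the expected step is a 1.0-fold higher number from compound 1 to compound 4 (0.02 log units; within the scatter). Compound 4 is estimated at 12000 nM, with a range from 5000 nM to 28000 nM.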

Compound 4, half-maximal inhibitory concentration: 19500 nM
Beside the measured number, compound 4's estimate is 1.6-fold (0.21 log units) below it; low and high end bracket the measured number.
By their numbers in this assay, from the lowest: compounds 1, 3, 4 and 2 (each within the scatter of the next).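

In this assay, replacing the earlier groups with 4-bromophenyl on a saturated chain carbon bound to a sulfur gives a 1.7-fold higher number from compound 1 to compound 4 (0.23 log units; within the scatter) and a 1.7-fold higher number from compound 3 to compound 4 (0.22 log units; within the scatter) and also a 1.1-fold lower number from compound 2 to compound 4 (0.04 log units; within the scatter) and so produces no step beyond the scatter from any earlier compound. The flat picture left by cyclohexyl, cyclopropyl and benzyl at this place therefore now also covers an aromatic ring carrying bromine, and the four compounds cannot be put in any order on this read-out. Nothing available bears on why the read-out stays this flat at this position.

Still open is whether a group with hydrogen-bond donors or acceptors at this place, such as an amine or a carboxylic acid, would give a step beyond the scatter, since every group shown has none of either. Also open, on these data alone, is whether a longer chain between the sulfur and the ring, or a change elsewhere on the shared core, would move the number outside the scatter of these four compounds.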